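Hydrogen in place of methyl: clearance notes

The source may report more compounds than this note shows. Statements on the series, on what has been measured and on what is new or still open speak of the compounds shown alone.

In an ADME assay on liver for metabolic stability, with Liver microsome (Rattus norvegicus) as the target, read by LC-MS, using microsomes, with a stated time of 5 h (on this read-out higher numbers stand for fast clearance and lower numbers for slow clearance), compound 1 `OC(c1ccccn1)C1(c2ccc(Cl)c(Cl)c2)CCOC1` gives 983 mL/min/kg and compound 2 `CN1CC(c2ccc(C(F)(F)F)cc2)(C(O)c2ccccn2)C1` gives 117 mL/min/kg, the lower of the two numbers and beyond the scatter. Compound 3 `OC(c1ccccn1)C1(c2ccc(C(F)(F)F)cc2)CNC1` differs from compound 2 by hydrogen in place of methyl on an amine nitrogen in a ring. Among the compounds with values here, no measured pair shows this change, so its size remains uncertain. The expected step is small, a 1.6-fold lower number from compound 2 to compound 3 (0.19 log units; within the scatter), a decrease that would stay within the scatter. For compound 3 the estimated clearance is 75 mL/min/kg, with an expected range of 25 mL/min/kg to 220 mL/min/kg.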

Compound 3, clearance: 50 mL/min/kg
Compound 3: middle estimate off by 1.5-fold (0.18 log units), on the high side, within the range that was stated.
By their numbers in this assay, from the lowest: compound 3; then compound 2; then compound 1.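

Within the data shown here, on the amine nitrogen of the four-membered non-aromatic ring, hydrogen in place of methyl gives a 2.3-fold lower number from compound 2 to compound 3 (0.37 log units; beyond the scatter) in this assay and is the only single-place step. Clearance therefore responds to this one change at this nitrogen, by a modest step that lies beyond the scatter. No measurement on hand accounts for the step.

Still open, as far as these compounds go, is how clearance moves with an ethyl or acetyl group on this nitrogen. One step on one pair also leaves open whether the same change holds with a different group in place of trifluoromethyl.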